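This account rests on a few compounds, and the source may have more. Where it says the series, first, only, none or still open, it means among the compounds named here.

Values in an ADME assay on MT4 cells (Homo sapiens) for cytotoxicity, read by MTT assay, with a stated time of 4 days; a lower number here means that less compound is tolerated, a higher number that more compound is tolerated:
- compound 1 `COc1ccccc1-c1oc2ccc(NC(C)=O)cc2c(=O)c1O`: 385000 nM
- compound 2 `COc1cccc(-c2oc3ccc(NC(C)=O)cc3c(=O)c2O)c1`: 33300 nM
- compound 3 `COc1ccccc1-c1oc2ccc(N)cc2c(=O)c1O`: 222000 nM

Compound 1 shares the top of this short range with compound 3, as shown by a 1.7-fold lower number from compound 1 to compound 3 (0.24 log units; within the scatter). Compound 2 sits clearly lower, with a 12-fold lower number from compound 1 to compound 2 (1.06 log units; beyond the scatter).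

Next is compound 4 `COc1ccccc1-c1oc2ccc(NC(C)=O)cc2c(=O)c1OC`, which turns hydroxy to methoxy: methyl in place of hydrogen on an oxygen on an aromatic ring. Going by the values given here, neither measured step changes this oxygen, so no direct precedent exists. Among the compounds with values here, the large step to compound 2, a 12-fold lower number from compound 1 to compound 2 (1.06 log units; beyond the scatter), shows only that one change can move this assay far, which argues for a wide range. Expected is a 1.8-fold lower number from compound 1 to compound 4 (0.24 log units; within the scatter), a modest drop within the scatter. For compound 4 the estimated value is 220000 nM, with an expected range of 70000 nM to 500000 nM.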

Compound 4, half-maximal cytotoxic concentration: 154000 nM
Compound 4: middle estimate off by 1.4-fold (0.15 log units), on the high side; measured number inside the range.
By their numbers in this assay, from the lowest: compound 2; then compounds 4, 3 and 1 (each within the scatter of the next, the first and the last beyond it).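

Methyl on this oxygen is the first change at this position, and in this assay it gives a 2.5-fold lower number from compound 1 to compound 4 (0.40 log units; beyond the scatter). So this hydroxy hydrogen can be replaced with a modest but real drop, which is the first evidence that the position affects the number. Nothing available explains this step.

Open, as far as these compounds go, is whether an ethyl group or a longer chain carrying an amine or a carboxylic acid on this oxygen would move the number further. Also open, from the compounds shown here alone, is whether methyl here gives a similar step in compound 2 or compound 3.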